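Replacing the Methylcarbamoyl Thiazolyl Group in Compound 2

The compounds below may be only part of what the source reports. "The series", "measured", "known", "first", "only" and "open" are said of these compounds alone.

In a functional assay on MCF7 cells (Homo sapiens) for antiproliferative activity (on this read-out lower numbers stand for stronger inhibition and higher numbers for weaker inhibition), compound 2 `CNC(=O)c1sc(N2N=C(c3ccc(C)cc3)CC2c2cc3cc(OC)ccc3nc2Cl)nc1C` gives 38 nM, level with compound 1 `COc1ccc2nc(Cl)c(C3CC(c4ccc(C)cc4)=NN3c3nc(-c4ccc(Cl)cc4)cs3)cc2c1` at 38 nM. Compound 3 `COc1ccc2nc(Cl)c(C3CC(c4ccc(C)cc4)=NN3c3nc(-c4ccc(C)cc4)cs3)cc2c1` has not yet been measured. Its structure departs from that of compound 2 in one place, where 4-(4-methylphenyl)-1,3-thiazol-2-yl stands in place of 4-methyl-5-(methylcarbamoyl)-1,3-thiazol-2-yl on an amine nitrogen in a ring: 4-(4-methylphenyl)-1,3-thiazol-2-yl in place of 4-methyl-5-(methylcarbamoyl)-1,3-thiazol-2-yl on an amine nitrogen in a ring. Among the measured compounds shown here, one measured step bears on this change: no change at the digits printed from compound 1 to compound 2 (within the scatter). Compound 1 carries 4-(4-chlorophenyl)-1,3-thiazol-2-yl at that place, so the entering group differs from it only in the substituent on the phenyl ring, and no measurement here isolates that difference. No step beyond the scatter is therefore expected in this assay, and the expected change is a 1.1-fold higher number from compound 2 to compound 3 (0.02 log units; within the scatter). For compound 3 the estimated value is 40 nM, with an expected range from 15 nM to 110 nM.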

Compound 3, half-maximal inhibitory concentration: 38 nM
For compound 3 the middle estimate is 1.1-fold (0.02 log units) above the measured one; measured number inside the range.
By their numbers in this assay, from the lowest: compounds 1, 2 and 3 (each within the scatter of the next).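

In this assay, exchanging 4-methyl-5-(methylcarbamoyl)-1,3-thiazol-2-yl for 4-(4-methylphenyl)-1,3-thiazol-2-yl on the amine nitrogen in a ring gives no change at the digits printed from compound 2 to compound 3 (within the scatter), so this second pair again shows that quite different thiazolyl groups at this place read alike. Among the compounds shown here, the new measurement also isolates the phenyl substituent that the earlier compounds left untested: methyl in place of chloro on an aromatic carbon gives no change at the digits printed from compound 1 to compound 3 (within the scatter). Nothing measured here explains why these groups read alike.

Still open, as far as these compounds go, is whether the level read-out would hold with an amine or a carboxylic acid on the phenyl ring of this group, or with a plain phenyl in place of the 1,3-thiazol-2-yl. All three compounds also carry the same 4-methylphenyl group, so its contribution remains unresolved.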